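The compounds below may be only part of what the source reports. "The series", "measured", "known", "first", "only" and "open" are said of these compounds alone.

In a functional assay on thoracic aorta (Rattus norvegicus, strain Wistar), with a stated time of 15 min (a higher number here means that more compound is needed for the effect, a lower number that less compound is needed), compound 1 `COc1ccc(Cl)cc1C(C)NC(=O)NS(=O)(=O)c1ccccc1` gives only a limit, > 300000 nM, not a number. Compound 3 `CCOc1ccc(Cl)cc1C(C)NC(=O)NS(=O)(=O)c1ccccc1` also gives only a limit, > 300000 nM. Compound 2 `COc1ccc(Cl)cc1C(C)NC(=O)N(C)S(=O)(=O)c1ccccc1` gives a true number, 7200 nM. This is an at least 41-fold lower number from compound 1 to compound 2 (1.61 log units; beyond the scatter), a large step from methyl in place of hydrogen on an amide-type nitrogen. The other measured step is a step that the two limits leave unreadable from compound 1 to compound 3. Compound 4 `COc1ccc(F)cc1C(C)NC(=O)NS(=O)(=O)c1ccccc1` carries a different change: fluoro in place of chloro on an aromatic carbon, para to a methoxy group. Neither measured step touches that carbon, so neither sizes this change. With the limit of > 300000 nM in this assay, at which 2 of the 3 values shown sit, no step beyond the scatter is expected. The expected result is a number no higher from compound 1 to compound 4 (the limit leaves the size open). For compound 4 the estimated value is 300000 nM, with an expected range of 80000 nM to 1000000 nM.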

Compound 4, half-maximal effective concentration: > 300000 nM
Compound 4 gave a limit, no number; the forecaster's own chance of this, stated with the estimate: 75%; the middle value lies on the limit itself.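

Going by these compounds alone, compound 1 and compound 4 both give only a limit, not a number, in this assay, so no step between them can be read. Going by these compounds, whether fluoro in place of chloro changes the concentration needed remains open.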